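Swapping the Para Group for Fluorine in a Dienamide Series

This account rests on a few compounds, and the source may have more. Where it says the series, first, only, none or still open, it means among the compounds named here.

Measured compounds:
- compound 1, `CN(C)c1ccc(/C=C/C=C/C(=O)N2CCCCC2)cc1`: 13.4%
- compound 2, `CSc1ccc(/C=C/C=C/C(=O)N2CCCCC2)cc1`: 11.8%
- compound 3, `O=C(/C=C/C=C/c1ccc(OC2CCCC2)cc1)N1CCCCC1`: 16.1%

All three share the same core and differ only in the group on the aromatic carbon. In an assay for inhibition of Polyunsaturated fatty acid 5-lipoxygenase (Homo sapiens), read by spectrophotometry, tested at 20 uM (on this read-out higher numbers stand for more inhibition at the one concentration tested (going by the name of the read-out) and lower numbers for less inhibition), compound 3 gives 16.1%. Among the compounds with values here, on paper that is the upper edge of the three numbers, but the step of a number 2.7 percentage points higher from compound 1 to compound 3 (within the scatter) and the step of a number 4.3 percentage points higher from compound 2 to compound 3 (within the scatter) are both within the scatter, as is a number 1.6 percentage points lower from compound 1 to compound 2 (within the scatter), so no compound in the set can be told apart from the others on this read-out.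

Compound 4, `O=C(/C=C/C=C/c1ccc(F)cc1)N1CCCCC1`, is the next member. It differs from compound 3 in one place: fluoro in place of cyclopentyloxy on an aromatic carbon. The change is therefore of the same kind as the three steps already seen, each of which swapped one group on the same aromatic carbon and each of which stayed within the scatter. A small group now replaces a larger one, and nothing in the measured steps points to a shift in either direction beyond the scatter.

Compound 4 is therefore expected to give 12% in this assay, within a range of 3% to 21%, an estimated step of a number 4.1 percentage points lower from compound 3 to compound 4 (within the scatter) that lies within the usual scatter.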

Compound 4, a percentage reported as inhibition, at one concentration (the size of the read-out at that concentration, not a potency): 48.7%
The estimate for compound 4 lay 36.7 percentage points below the measured number, outside the stated range (above it).
By their numbers in this assay, from the lowest: compounds 2, 1 and 3 (each within the scatter of the next); then compound 4.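

In this assay, this aromatic carbon proves far from indifferent to the group it carries: the three earlier groups could not be told apart, but fluoro stands clear of each, with a number 32.6 percentage points higher from compound 3 to compound 4 (beyond the scatter), a number 36.9 percentage points higher from compound 2 to compound 4 (beyond the scatter) and a number 35.3 percentage points higher from compound 1 to compound 4 (beyond the scatter), all three large. The jump appears whether the group leaving holds a ring, as cyclopentyloxy does, or holds none, as with dimethylamino and methylsulfanyl, so the loss of that ring alone cannot account for the whole pattern. Nothing available here gives a measured property that would explain why fluoro stands apart from the other three groups.

The compounds shown leave open whether this jump belongs to fluorine in particular or would also appear with chlorine, bromine, a methyl group or plain hydrogen on the same carbon. They also leave open how potent compound 4 really is, since a percentage at one concentration gives the size of the effect at that concentration and not a potency.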